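From pyrrolidin-1-yl to diethylamino on the shared core

The source may report more compounds than this note shows. Statements on the series, on what has been measured and on what is new or still open speak of the compounds shown alone.

Compound 1 `CCN(CC)CCNC(=O)CC(CC(=O)NC1Cc2ccccc2C1)c1ccc(Cl)cc1`: 75000 nM
Compound 2 `O=C(CC(CC(=O)NC1Cc2ccccc2C1)c1ccccc1)NCCN1CCCCC1`: > 100000 nM, a limit
Compound 3 `O=C(CC(CC(=O)NC1Cc2ccccc2C1)c1ccccc1)NCCN1CCCC1`: > 100000 nM, a limit

All three compounds were tested in a functional assay on MCF7 cells (Homo sapiens) for inhibition; on this read-out lower numbers stand for stronger inhibition and higher numbers for weaker inhibition. Compound 3 stands at the limit of > 100000 nM in this assay, at which 2 of the 3 values shown sit. That entry is a limit of the assay and not a number, and the same is true of compound 2. Only compound 1 gives a true number, 75000 nM.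

Compound 4 `CCN(CC)CCNC(=O)CC(CC(=O)NC1Cc2ccccc2C1)c1ccccc1` has not been measured yet and brings one change to compound 3: diethylamino in place of pyrrolidin-1-yl on a saturated chain carbon, two bonds along the chain from an amide-type nitrogen. In words, this is diethylamino in place of pyrrolidin-1-yl on a saturated chain carbon, two bonds along the chain from an amide-type nitrogen.

The nearest measured change is a step that the two limits leave unreadable from compound 2 to compound 3. It alters the group at this same place, but it offers no size to carry over. Compound 1 also carries the diethylamino group and gives 75000 nM, but its structure is not identical to that of compound 4, so it is only a loose guide. At most a small gain in inhibition is therefore expected, and another report of only a limit is quite likely. The expected step is a number no higher from compound 3 to compound 4 (the limit leaves the size open). Compound 4 is estimated at 100000 nM, with an expected range from 50000 nM to 200000 nM.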

Compound 4, half-maximal inhibitory concentration: > 100000 nM
Compound 4 gave a limit, no number; the forecaster's own chance of this, stated with the estimate: 60%; the middle value lies on the limit itself.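

In this assay compound 4 gives > 100000 nM, which is a limit of the assay and not a number. Going by these compounds alone, the steps among compound 2, compound 3 and compound 4 cannot be read, so neither ring amine, piperidin-1-yl or pyrrolidin-1-yl, can be told apart from the open-chain diethylamino group at this place, and the series now gathers at one ceiling: the limit of > 100000 nM in this assay, at which 3 of the 4 values shown sit. The one readable step, hydrogen in place of chloro on an aromatic carbon, is an at least 1.3-fold higher number from compound 1 to compound 4 (0.12 log units; that floor lies within the scatter), which adds a first hint about the chloro group but does not establish that it matters, and the true size of the step stays hidden behind the limit.

Still open, going by these compounds, is whether chloro on the aromatic ring would give a true number with piperidin-1-yl or pyrrolidin-1-yl at the chain end, as it does with diethylamino in compound 1. The compounds shown also say nothing about how bromo or methoxy would read on that aromatic carbon, or how morpholin-4-yl would read in place of diethylamino.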